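The compounds below may be only part of what the source reports. "The series", "measured", "known", "first", "only" and "open" are said of these compounds alone.

Compound 1 `C#CCSc1nnc(C)n1N1C(=O)c2ccccc2C1=O`: in a functional assay on A549 cells (Homo sapiens) for cytotoxicity, read by MTT assay, with a stated time of 48 h (a lower number here means a stronger inhibitor, a higher number a weaker inhibitor), compound 1 gives > 200000 nM, which is a limit of the assay and not a number.
Compound 2 `C#CCSc1nnc(CC)n1N1C(=O)c2ccccc2C1=O`: in this assay compound 2 gives > 200000 nM, again a limit.
Compound 3 `CCCc1nnc(SCC(=O)c2ccc(Cl)cc2)n1N1C(=O)c2ccccc2C1=O`: in this assay compound 3 gives > 200000 nM, also a limit.

Compound 3 thus stands at the limit of this assay, the point at which every value shown so far sits (the limit of > 200000 nM in this assay, at which 3 of the 3 values shown sit). For the measured compounds named here, the only step between two measured compounds, a step that the two limits leave unreadable from compound 1 to compound 2, runs from one limit to another, so its size cannot be read. Compound 4 `C#CCSc1nnc(CCC)n1N1C(=O)c2ccccc2C1=O` differs from compound 3 by ethynyl in place of (4-chlorophenyl)carbonyl on a saturated chain carbon bound to a sulfur. Going by the values given here, no measured step bears directly on this change. What is known is that compound 1 and compound 2, which carry the same propargyl group as compound 4, and compound 3, which shares the remainder of its structure, all sit at the limit (the limit of > 200000 nM in this assay, at which 3 of the 3 values shown sit). In this assay compound 4 is therefore expected to remain at or beyond that limit as well, and the step from compound 3 to compound 4 is estimated as a step that the limit leaves unreadable from compound 3 to compound 4, a step that the limit is unlikely to let anyone read. Compound 4 is expected to give about 300000 nM, within a range of 100000 nM to 1000000 nM.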

Compound 4, half-maximal inhibitory concentration: > 200000 nM
Compound 4 was reported as a limit; the forecaster's own chance of this, stated with the estimate: 90%; the middle value lies beyond the limit too.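

In this assay compound 4 gives > 200000 nM, a limit and not a number, so its steps from compound 1, compound 2 and compound 3 cannot be read. The four compounds share one limit: the limit of > 200000 nM in this assay, at which 4 of the 4 values shown sit. The compounds shown leave open how large any of these steps is and which change, if any, would give a readable value in this assay.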